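One Added Methyl on a Compound at the Limit

The compounds below may be only part of what the source reports. "The series", "measured", "known", "first", "only" and "open" are said of these compounds alone.

In an ADME assay on RPTEC cells (Homo sapiens) for cytotoxicity, read by resazurin assay, with a stated time of 4 days (a higher number here means that more compound is tolerated, a lower number that less compound is tolerated), compound 3 `Cc1nc2ccccc2n1-c1ccc(C(=O)NC2CC2)s1` reads > 62000 nM as a limit, not a number. Compound 1 `CCCNC(=O)c1ccc(-n2cnc3ccccc32)s1` reads > 62000 nM as a limit too. Compound 2 `O=C(NC1CCC1)c1ccc(-n2cnc3ccccc32)s1` likewise reads > 62000 nM as a limit. The change to compound 4 `CCc1nc2ccccc2n1-c1ccc(C(=O)NC2CC2)s1` is methyl in place of hydrogen on a saturated chain carbon bound to an aromatic carbon and turns methyl to ethyl. Going by the values given here, the one measured step, a step that the two limits leave unreadable from compound 1 to compound 2 and made on an amide-type nitrogen, gives no size to carry over. The remaining evidence is the limit of > 62000 nM in this assay, at which 3 of the 3 values shown sit, and offers no size either. The estimated step in this assay is a number no higher from compound 3 to compound 4 (the limit leaves the size open) and none beyond the scatter is expected. Compound 4 is expected at 62000 nM within an estimated range of 35000 nM to 100000 nM and will probably again be reported only as a limit.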

Compound 4, concentration lethal to 50% of the cells: > 62000 nM
Compound 4 gave a limit, no number; the forecaster's own chance of this, stated with the estimate: 80%; the middle value lies on the limit itself.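

Going by these compounds alone, compound 3 and compound 4 both read only as limits in this assay, so no step between them can be read. The compounds shown leave open whether going from methyl to ethyl changes the tolerated concentration at all.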